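Urea aryl replacement: methanesulfonamidophenyl for trifluoromethylphenyl

This account rests on a few compounds, and the source may have more. Where it says the series, first, only, none or still open, it means among the compounds named here.

Measured compounds:
compound 1 `CC(=O)Nc1ccc(S(=O)(=O)Nc2cccc(-c3nc(-c4ccc(NC(=O)c5cccnc5)cc4Cl)no3)c2)cc1C`: > 10000 nM
compound 2 `O=C(Nc1cccc(-c2nc(-c3ccc(NC(=O)c4cccnc4)cc3Cl)no2)c1)Nc1cccc(C(F)(F)F)c1`: 1900 nM
compound 3 `O=C(Nc1cccc(-c2nc(-c3ccc(NC(=O)c4cccnc4)cc3Cl)no2)c1)Nc1cc(C(F)(F)F)cc(C(F)(F)F)c1`: 1900 nM

In a functional assay on MDA-MB-231 cells (Homo sapiens) for antiproliferative activity, read by MTT assay, with a stated time of 72 h (on this read-out higher numbers stand for weaker inhibition and lower numbers for stronger inhibition), compound 2 gives 1900 nM. In the same assay compound 3 gives 1900 nM, and the step of no change at the digits printed from compound 2 to compound 3 (within the scatter) leaves compound 2 and compound 3 level at the digits shown. The value of compound 1 is a limit of this assay, (the limit of > 10000 nM in this assay, at which 1 of the 3 values shown sits), and it rests on a different linker, so it does not bear on the urea series.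

Compound 4 `CS(=O)(=O)Nc1ccc(NC(=O)Nc2cccc(-c3nc(-c4ccc(NC(=O)c5cccnc5)cc4Cl)no3)c2)cc1` is not yet measured. It differs from compound 2 by 4-(methanesulfonamido)phenyl in place of 3-(trifluoromethyl)phenyl on an amide-type nitrogen. For the measured compounds named here, the only measured step in this part of the molecule, from compound 2 to compound 3, adds a second trifluoromethyl and produces no change beyond the scatter. Going by the values given here, the exchange to 4-(methanesulfonamido)phenyl is a larger change, with 1 hydrogen-bond donor and 2 hydrogen-bond acceptors entering where none leave, and no measured step informs its direction. The expected step of a 1.3-fold higher number from compound 2 to compound 4 (0.12 log units; within the scatter) is therefore set near zero, with a wide range. Compound 4 is expected to give about 2500 nM in this assay, between 800 nM and 12000 nM.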

Compound 4, half-maximal inhibitory concentration: 600 nM
Compound 4: the middle estimate sits 4.2-fold (0.62 log units) above what was measured; the whole stated range lies above it.
By their numbers in this assay, from the lowest: compound 4; then compounds 2 and 3 (each within the scatter of the next). At a limit, above all of these: compound 1.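

In this assay, for the compounds shown here, the aryl group on an amide-type nitrogen proves able to move the number, since the exchange gives a 3.2-fold lower number from compound 2 to compound 4 (0.50 log units; beyond the scatter), whereas the only earlier step at this place, no change at the digits printed from compound 2 to compound 3 (within the scatter), did not. A trifluoromethyl on this phenyl is therefore not needed for a value at this level, and a group carrying a hydrogen-bond donor and acceptors is tolerated here in compound 4. No measurement at hand accounts for this step.

The compounds shown do not separate the effect of the methanesulfonamido group from that of its place in the name, 4- rather than 3-, as both differ between compound 2 and compound 4. Going by these compounds, how a carboxylic acid or an amine on the same phenyl would read in this assay remains open.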